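From naphthalen-1-yl to phenyl, measured only at limits

A few compounds are considered here, and "the series" means these few. Any claim that something is new, unique, unknown or untested is made for them only; others in the source may bear on it.

Compound 1 `COc1ccc(S(=O)(=O)Oc2ccccc2/C=C(\C#N)C(=O)Nc2nnc(-c3cccs3)s2)cc1` gives > 20000 nM (a limit)
Compound 2 `COc1ccc(S(=O)(=O)Oc2ccccc2/C=C(\C#N)C(=O)Nc2nnc(Cc3cccc4ccccc34)s2)cc1` gives > 50000 nM (a limit)

Both readings come from an ADME assay on HEK-293T cells (Homo sapiens) for inhibition, read by CCK-8 assay, with a stated time of 48 h (on this read-out higher numbers stand for weaker inhibition and lower numbers for stronger inhibition), and neither is a number. Among the compounds with values here, compound 2 stands at > 50000 nM as a limit of the assay, and the only other value shown is a limit as well. Compound 3 `COc1ccc(S(=O)(=O)Oc2ccccc2/C=C(\C#N)C(=O)Nc2nnc(Cc3ccccc3)s2)cc1` departs from compound 2 by one change: phenyl in place of naphthalen-1-yl on a saturated chain carbon bound to an aromatic carbon. Within the data shown here, the one measured step that bears on this is a step that the two limits leave unreadable from compound 1 to compound 2 and it offers no size to carry over. No direction can therefore be expected in this assay and no step beyond the scatter is expected either. The step expected is an at least 1.2-fold lower number from compound 2 to compound 3 (0.09 log units; that floor lies within the scatter) and it rests on the limit of compound 2 alone. Compound 3 is expected at 40000 nM with an estimated range from 15000 nM to 100000 nM in this read-out, and it may again return only a limit.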

Compound 3, half-maximal inhibitory concentration: > 50000 nM
Compound 3: a limit, no number (the forecaster's own chance of this, stated with the estimate: 70%); at least 1.2-fold (0.09 log units) between middle value and limit.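

No step can be read between compound 1, compound 2 and compound 3, as all three return only limits in this assay. The compounds shown leave open whether thiophen-2-yl, (naphthalen-1-yl)methyl and benzyl differ at all in this read-out, and in which direction.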